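Swapping the ketone-side ring in a benzothiazole enaminone

The source may report more compounds than this note shows. Statements on the series, on what has been measured and on what is new or still open speak of the compounds shown alone.

Of the compounds shown here, two of one shared core have been tested in a functional assay on MDA-MB-231 cells (Homo sapiens) for antiproliferative activity, read by sulforhodamine B assay, with a stated time of 48 h; a higher number here means a weaker inhibitor, a lower number a stronger inhibitor. Compound 1 `COc1cc(C(=O)/C=C\Nc2ccc(-c3nc4cc(OC)c(OC)c(OC)c4s3)cc2C)cc(OC)c1OC` gives 12900 nM in this assay. For the measured compounds named here, compound 2 `COc1ccc(C(=O)/C=C\Nc2ccc(-c3nc4cc(OC)c(OC)c(OC)c4s3)cc2)cc1[N+](=O)[O-]` gives 17100 nM in this assay; this pair differs in more than one place, so no single step can be drawn between them, and their two values lie within the scatter of each other, so neither can be called the stronger inhibitor.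

Compound 3 `COc1ccc(C(=O)/C=C\Nc2ccc(-c3nc4cc(OC)c(OC)c(OC)c4s3)cc2C)cc1O` has not yet been measured. It departs from compound 1 in one place: 3-hydroxy-4-methoxyphenyl in place of 3,4,5-trimethoxyphenyl on a carbonyl carbon. Going by the values given here, nothing among the measured compounds tests this particular exchange, so the expectation for compound 3 rests only on the value of compound 1 and the size of the change itself.

The expected step from compound 1 to compound 3 in this assay is a 1.6-fold higher number from compound 1 to compound 3 (0.19 log units; within the scatter), a mild weakening that may not exceed the scatter. Compound 3 is therefore estimated to give 20000 nM in this assay, with a plausible range from 6000 nM to 60000 nM.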

Compound 3, half-maximal inhibitory concentration: 12400 nM
Beside the measured number, compound 3's estimate is 1.6-fold (0.21 log units) above it; low and high end bracket the measured number.
By their numbers in this assay, from the lowest: compounds 3, 1 and 2 (each within the scatter of the next).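

For the compounds shown here, compound 1 and compound 3 differ only on the carbonyl carbon, so this pair gives the first clean reading of a single change at this position; compound 1 and compound 2 differ in more than one place and could not give one. In this assay, exchanging 3,4,5-trimethoxyphenyl for 3-hydroxy-4-methoxyphenyl gives a 1.0-fold lower number from compound 1 to compound 3 (0.02 log units; within the scatter), so this smaller group, which carries a hydrogen-bond donor that the leaving group lacks, leaves no readable difference in antiproliferative activity. Going by these compounds alone, no supporting measurement is available to explain this outcome, so the result records only that the exchange was tolerated in this one comparison.

Going by these compounds, one exchange cannot show how much freedom this position allows, so it remains open whether a phenyl ring bearing an amine or a carboxylic acid on the same carbonyl carbon, or a longer chain in place of the ring, would move the number beyond the scatter. On these data alone, it is also open whether the same exchange would read alike on a different core or in other cell lines.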